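Pyrazole series: lipophilicity notes on the amide swap

This account rests on a few compounds, and the source may have more. Where it says the series, first, only, none or still open, it means among the compounds named here.

Measured compounds in a physicochemical assay for lipophilicity, at pH 7.4; on this read-out lower numbers stand for lower lipophilicity and higher numbers for higher lipophilicity:
compound 1 `Cc1cc(C(=O)O)nn1Cc1cc(Br)ccc1OCc1ccccc1`, 1.2
compound 2 `Cc1cc(C(=O)Nc2ccccn2)nn1Cc1cc(Cl)ccc1OCc1ccccc1`, > 3.7
compound 3 `Cc1cc(C(=O)NN2CCCCC2)nn1Cc1cc(Cl)ccc1OCC(C)C`, 3.3

Compound 1, the free acid, sits lowest of the three in this assay at 1.2. Compound 3, with its isobutoxy ether and the hydrazide to piperidine, gives 3.3 in this assay. For the measured compounds named here, compound 2 gives > 3.7 in this assay, which is a limit of the method and not a number; it is the one value here that reaches the ceiling (the limit of > 3.7 in this assay, at which 1 of the 3 values shown sits). Compound 2 therefore stands at the top of what has been measured, but how far it actually lies is not known.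

Compound 4 `Cc1cc(NC(=O)CC2CCCCC2)nn1Cc1cc(Cl)ccc1OCc1ccccc1` is the next point. It differs from compound 2 in one place: ((cyclohexylmethyl)carbonyl)amino in place of (pyridin-2-yl)carbamoyl on an aromatic carbon. The change leaves the benzyloxy aryl part and the chloro substituent untouched and exchanges one group on the shared core for another of similar size, the entering group carrying one six-membered non-aromatic ring of carbon only where the leaving group carried a pyridine ring.

Going by the values given here, no measured pair here shows this particular exchange, so the size of the step is open. In this assay a step upward, or none beyond the scatter, is expected, not a fall back toward the value of compound 3 or compound 1. Compound 4 is estimated at 4.1, with a range of 3.6 to 4.6, which means an expected step that the limit leaves unreadable from compound 2 to compound 4. Given that compound 2 already reports only a limit (the limit of > 3.7 in this assay, at which 1 of the 3 values shown sits), the likeliest outcome for compound 4 is again a limit rather than a number.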

Compound 4, distribution coefficient: 3.2
The estimate for compound 4 lay 0.90 log units above the measured number; the whole stated range lies above it.
By their numbers in this assay, from the lowest: compound 1; then compounds 4 and 3 (each within the scatter of the next). At a limit, above all of these: compound 2.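

Compound 2 gives > 3.7 in this assay, which is a limit and not a number. With ((cyclohexylmethyl)carbonyl)amino in place of (pyridin-2-yl)carbamoyl on an aromatic carbon, the series shows a number at least 0.50 log units lower from compound 2 to compound 4 (beyond the scatter), the first step read at this place on the shared core, and it shows that an exchange here alone, with the benzyloxy aryl part and the chloro substituent untouched, brings the read-out from the limit to a number. The full size of this step stays unknown, and only its lower bound can be read, because one end of it rests on a limit: the limit of > 3.7 in this assay, at which 1 of the 4 values shown sits.

The exchange alters the ring and the amide link in one step, so the compounds shown do not separate what each contributes to the change in this assay. A phenyl ring in place of the cyclohexyl ring, or a longer chain between the carbonyl and the cyclohexyl ring, would be needed to tell these contributions apart at this place.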